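Methoxy added to the bromo chalcone of compound 3

A few compounds are considered here, and "the series" means these few. Any claim that something is new, unique, unknown or untested is made for them only; others in the source may bear on it.

Measured so far in a functional assay on MCF7 cells (Homo sapiens) for antiproliferative activity, read by sulforhodamine B assay, with a stated time of 72 h, tested at 10 uM; on this read-out lower numbers stand for a stronger effect and higher numbers for a weaker effect at the one concentration tested:
compound 1 `COc1cc(Br)cc(/C=C/C(=O)c2ccc(Cl)cc2)c1O`: 53.3%
compound 2 `COc1cc(Br)cc(/C=C/C(=O)c2ccc(C)cc2)c1O`: 96.8%
compound 3 `O=C(/C=C/c1cc(Br)ccc1O)c1ccc(Br)cc1`: 28.7%

Compound 3 stands lowest of the three numbers, and both gaps to the other two lie beyond the scatter; the nearest is compound 1 and the furthest compound 2. Going by the values given here, the one step measured within one change, a number 43.5 percentage points higher from compound 1 to compound 2 (beyond the scatter), concerns the halogen on the ketone ring and does not touch the position altered here.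

Compound 4 `COc1cc(Br)cc(/C=C/C(=O)c2ccc(Br)cc2)c1O` is compound 3 with the change (methoxy in place of hydrogen on an aromatic carbon). Among the compounds with values here, no measured pair isolates this change: the methoxy is present in compound 1 but absent in compound 3, and the halogen on the ketone ring differs between them as well, so the gap between compound 1 with 53.3% and compound 3 with 28.7% cannot be split between the two differences. The expectation therefore rests on weak ground. Compound 3 with its bromo on the ketone ring sits at the strong end, and compound 1 with the methoxy present sits higher, so a step of a number 11.3 percentage points higher from compound 3 to compound 4 (beyond the scatter) toward the weaker side is expected, with the direction itself uncertain. For compound 4 the estimate is 40%, within 20% to 65%.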

Compound 4, a percentage reported as activity, at one concentration (the size of the read-out at that concentration, not a potency): 64.6%
For compound 4 the middle estimate is 24.6 percentage points below the measured one; the range from low to high includes it.
By their numbers in this assay, from the lowest: compound 3; then compound 1; then compound 4; then compound 2.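

Notes on the methoxy position: in this assay, methoxy in place of hydrogen on an aromatic carbon, ortho to a hydroxy group and meta to a bromo group, can now be read on its own, with the bromo on the ketone ring held constant, and it gives a number 35.9 percentage points higher from compound 3 to compound 4 (beyond the scatter), a large move toward the weaker side. With the methoxy kept, the group on the ketone ring now has three measured members: bromo in place of methyl gives a number 32.2 percentage points lower from compound 2 to compound 4 (beyond the scatter), while bromo in place of chloro gives a number 11.3 percentage points higher from compound 1 to compound 4 (beyond the scatter), so the two halogens lie closer to each other than either lies to methyl, though their gap is still beyond the scatter. The data on hand offer no explanation for any of these steps.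

As far as these compounds go, whether the methoxy step keeps its size with chloro or methyl on the ketone ring stays open, as only the bromo pair isolates it. Also open, from the compounds shown here alone, is how an amine or a longer ether chain such as propoxy would read at this same place on the ring.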